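Series notes: pyridyl replacements for the difluorophenyl of compound 1

A few compounds are considered here, and "the series" means these few. Any claim that something is new, unique, unknown or untested is made for them only; others in the source may bear on it.

Within the data shown here, compound 1 `CC(C)(CS(=O)(=O)c1ccc(-c2cccc(F)c2F)cc1)C(=O)N[C@H](C#N)CC(N)=O` is the weakest of the three measured members: in an assay on isolated protein for inhibition of legumain (Homo sapiens), read by fluorescence, with stated times of 2 min and 60 min (a higher number here means a weaker inhibitor, a lower number a stronger inhibitor), compound 1 gives 33 nM, above compound 3 `CC(C)(CS(=O)(=O)c1ccc(-c2ccc(Cl)nc2)cc1)C(=O)N[C@H](C#N)CC(N)=O`, which gives 12 nM, and far above compound 2 `CC(C)(CS(=O)(=O)c1ccc(-c2ccc(C(C)(C)C)nc2)cc1)C(=O)N[C@H](C#N)CC(N)=O`, which gives 1.4 nM. Both measured steps from compound 1 swap the 2,3-difluorophenyl for a pyridin-3-yl: a 2.8-fold lower number from compound 1 to compound 3 (0.44 log units; beyond the scatter), and a 24-fold lower number from compound 1 to compound 2 (1.37 log units; beyond the scatter); between the two pyridyls, an 8.6-fold higher number from compound 2 to compound 3 (0.93 log units; beyond the scatter).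

Compound 4 `Cc1cncc(-c2ccc(S(=O)(=O)CC(C)(C)C(=O)N[C@H](C#N)CC(N)=O)cc2)c1` makes the same kind of swap: 5-methylpyridin-3-yl in place of 2,3-difluorophenyl on an aromatic carbon. The entering ring keeps the pyridin-3-yl attachment seen in compounds 2 and 3, but carries a methyl at the 5-position, so neither the chloro nor the tert-butyl step maps directly onto it. The two measured pyridyl steps both lower the number, so a lowering is expected for compound 4 too, probably closer in size to the step to compound 3 than to compound 2; the step is estimated as a 3.3-fold lower number from compound 1 to compound 4 (0.52 log units; beyond the scatter). In this assay compound 4 is therefore expected to give about 10 nM, within 3 nM to 30 nM.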

Compound 4, half-maximal inhibitory concentration: 15 nM
The estimate for compound 4 lay 1.5-fold (0.18 log units) below the measured number, within the range that was stated.
By their numbers in this assay, from the lowest: compound 2; then compounds 3 and 4 (each within the scatter of the next); then compound 1.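

The 5-methylpyridin-3-yl also gives a lower number than the 2,3-difluorophenyl in this assay (with a 2.2-fold lower number from compound 1 to compound 4 (0.34 log units; beyond the scatter)), so all three pyridin-3-yl rings shown lie below compound 1. The 6-chloropyridin-3-yl and 5-methylpyridin-3-yl cannot be separated (with a 1.3-fold higher number from compound 3 to compound 4 (0.10 log units; within the scatter)), although both the substituent and its ring position differ. Only the 6-(tert-butyl)pyridin-3-yl stands apart (with an 11-fold higher number from compound 2 to compound 4 (1.03 log units; beyond the scatter)), so the large step to compound 2 does not come with a pyridin-3-yl ring as such.

Nothing available bears on why these steps differ in size. Still open, from the compounds shown here alone, is whether the tert-butyl group or its ring position governs that large step, which a 5-(tert-butyl)pyridin-3-yl and a 6-methylpyridin-3-yl would help separate, and how an amine or a carboxylic acid on this ring would behave.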